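Adding a methoxy to compound 3

The source may report more compounds than this note shows. Statements on the series, on what has been measured and on what is new or still open speak of the compounds shown alone.

Values in a functional assay on NCI/ADR-RES cells (Homo sapiens) for inhibition, read by sulforhodamine B assay, with a stated time of 48 h; a higher number here means a weaker inhibitor of growth, a lower number a stronger inhibitor of growth:
- compound 1 `CC1(/C=C/c2ccccc2C(F)(F)F)C=CC(=O)O1` gives 12200 nM
- compound 2 `CC1(/C=C/c2ccc(C(F)(F)F)cc2)C=CC(=O)O1` gives 9400 nM
- compound 3 `COc1ccc(/C=C/C2(C)C=CC(=O)O2)c(OC)c1` gives 151000 nM

Compound 3 carries the highest number of the three, and its gaps to compound 1 and compound 2 lie beyond the scatter. Compound 4 `COc1cc(OC)c(OC)cc1/C=C/C1(C)C=CC(=O)O1` differs from compound 3 by one change, methoxy in place of hydrogen on an aromatic carbon. Among the compounds with values here, no measured pair shows a change of this kind, so any forecast in this assay is loose. A modest move toward a lower number is expected, resting only on compound 3 standing high at 151000 nM, though a step within the scatter remains possible. The expected step is a 1.9-fold lower number from compound 3 to compound 4 (0.28 log units; within the scatter). The estimated value for compound 4 is 80000 nM, with an expected range from 18000 nM to 300000 nM.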

Compound 4, concentration for total growth inhibition: 158000 nM
The estimate for compound 4 lay 2.0-fold (0.30 log units) below the measured number; the measured number falls inside the stated range.
By their numbers in this assay, from the lowest: compounds 2 and 1 (each within the scatter of the next); then compounds 3 and 4 (each within the scatter of the next).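

In this assay, methoxy in place of hydrogen on this aromatic carbon, ortho to a methoxy group and para to a methoxy group, gives a 1.0-fold higher number from compound 3 to compound 4 (0.02 log units; within the scatter). This is the only one-place pair shown, and at this position the added methoxy does not separate the two compounds. No available data explain this result.

As far as these compounds go, whether a hydroxyl, an amine or a chlorine on this carbon would separate from compound 3 remains open. So does whether methoxy on another aromatic carbon would behave in the same way.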